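The source may report more compounds than this note shows. Statements on the series, on what has been measured and on what is new or still open speak of the compounds shown alone.

Measured compounds in the series:
- compound 1, `OC[C@H]1OC(n2cnc3c(-c4ccc(Cl)cc4)ncnc32)[C@H](O)[C@@H]1O` — 900 nM
- compound 2, `Cc1csc(-c2ncnc3c2ncn3C2O[C@H](CO)[C@@H](O)[C@H]2O)n1` — 6000 nM
- compound 3, `Cc1cc(-c2ncnc3c2ncn3C2O[C@H](CO)[C@@H](O)[C@H]2O)on1` — "not active" (no number reported)

The read-out throughout is a functional assay on CCRF-CEM cells (Homo sapiens) for inhibition; a lower number here means a stronger inhibitor, a higher number a weaker inhibitor. Among the compounds with values here, compound 1 gives 900 nM in this assay, compound 2 gives 6000 nM, and the one measured step between them, a 6.7-fold higher number from compound 1 to compound 2 (0.82 log units; beyond the scatter), replaces a 4-chlorophenyl with a 4-methyl-1,3-thiazol-2-yl on the shared core. Compound 3, carrying a 3-methyl-1,2-oxazol-5-yl at the same place, is reported only as "not active" (no number reported): no single number exists for it, so it stands below anything quantified here.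

Compound 4, `Cn1nccc1-c1ncnc2c1ncn2C1O[C@H](CO)[C@@H](O)[C@H]1O`, is not yet measured. It differs from compound 3 by 1-methyl-1H-pyrazol-5-yl in place of 3-methyl-1,2-oxazol-5-yl on an aromatic carbon, the new group sitting on the aromatic carbon of the six-membered ring next to the ring nitrogen, ortho to a fused ring. Within the data shown here, no measured step covers a five-membered ring swapped for another five-membered ring; the only step, from compound 1 to compound 2, shows that a five-membered heteroaryl in this position weakens inhibition relative to compound 1. Given that compound 3 is inactive and compound 2 weak, compound 4 is expected to be weak in this assay, with a sizeable chance that no number is returned.

Compound 4 is estimated at 15000 nM, within 3000 nM to 60000 nM.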

Compound 4, half-maximal inhibitory concentration: "not active" (no number reported)
Compound 4: no number reported; the estimate stays without a comparison.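

Compound 3 and compound 4 are both reported only as "not active" in this assay, so no step can be read between them. No evidence shown bears on this result. The compounds shown leave open whether 1-methyl-1H-pyrazol-5-yl and 3-methyl-1,2-oxazol-5-yl differ at all in this read-out.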